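Swapping the urea arm of compound 1 for a furan amide

The compounds below may be only part of what the source reports. "The series", "measured", "known", "first", "only" and "open" are said of these compounds alone.

Compound 1 `O=C(Nc1ccc(Cl)cc1)Nc1c(C(O)(C(F)(F)F)C(F)(F)F)ccc2ccccc12` is a urea; measured in an assay on LtK cells with ATP-sensitive inward rectifier potassium channel 11 (Homo sapiens) as the target (on this read-out higher numbers stand for an effect only at larger amounts of compound and lower numbers for an effect already at smaller amounts), compound 1 gives 276 nM. Two amides share its core. Compound 2 `COc1ccc(C(=O)Nc2c(C(O)(C(F)(F)F)C(F)(F)F)ccc3ccccc23)cc1` gives 417 nM in this assay, and compound 3 `O=C(Nc1c(C(O)(C(F)(F)F)C(F)(F)F)ccc2ccccc12)c1ccc(Cl)c(Cl)c1` gives 194 nM. Among these three numbers compound 1 stands second highest, with compound 3 nearest and compound 2 furthest, both within the scatter of it. Compound 4 `O=C(Nc1c(C(O)(C(F)(F)F)C(F)(F)F)ccc2ccccc12)c1ccco1` carries the change (furan-2-yl in place of (4-chlorophenyl)amino on a carbonyl carbon). Going by the values given here, the steps that bear on this change are the two that likewise replace the (4-chlorophenyl)amino group on the carbonyl carbon with an aryl group: a 1.5-fold higher number from compound 1 to compound 2 (0.18 log units; within the scatter) and a 1.4-fold lower number from compound 1 to compound 3 (0.15 log units; within the scatter). Between the two amides, a 2.1-fold lower number from compound 2 to compound 3 (0.33 log units; beyond the scatter). Those aryl replacements left the number close to that of compound 1, and the furan-2-yl group is the smallest of the groups entering at this place, so only a small step upward is expected, a 1.8-fold higher number from compound 1 to compound 4 (0.26 log units; within the scatter). Compound 4 is therefore estimated at 500 nM in this assay, within a range from 200 nM to 1500 nM.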

Compound 4, half-maximal effective concentration: 9 nM
Compound 4: the middle estimate sits 56-fold (1.74 log units) above what was measured, outside the stated range (below it).
By their numbers in this assay, from the lowest: compound 4; then compounds 3, 1 and 2 (each within the scatter of the next, the first and the last beyond it).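

The group on the carbonyl carbon matters far more in this assay than compounds 1, 2 and 3 suggested: a 31-fold lower number from compound 1 to compound 4 (1.49 log units; beyond the scatter) and a 22-fold lower number from compound 3 to compound 4 (1.33 log units; beyond the scatter) and also a 46-fold lower number from compound 2 to compound 4 (1.67 log units; beyond the scatter) are all large steps. Going by these compounds alone, the (4-chlorophenyl)amino, 4-methoxyphenyl and 3,4-dichlorophenyl groups kept their numbers close together, and furan-2-yl, the only five-membered aromatic ring here and the only group with a ring hetero atom, gives compound 4 the lowest number of the four. No measurement shown accounts for this drop.

On these data alone, what remains open is whether the low number depends on the ring oxygen, on where the ring is attached, or on the size of the ring. A thiophen-2-yl, a furan-3-yl or a plain phenyl group at this place would separate these possibilities.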